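This account rests on a few compounds, and the source may have more. Where it says the series, first, only, none or still open, it means among the compounds named here.

Compound 1 `COc1ccc(C2CC(c3cccc4ccccc34)=NN2C(C)=O)c(OC)c1OC` gives 1220 nM in a functional assay on PC-3 cells (Homo sapiens) for cytotoxicity, read by sulforhodamine B assay, with a stated time of 48 h; a lower number here means a stronger inhibitor, a higher number a weaker inhibitor.
Compound 2 `COc1ccc(C2CC(c3cccc4ccccc34)=NN2C(C)=O)cc1OC` gives 2010 nM.
Compound 3 `COc1ccc(C2CC(c3ccc4ccccc4c3)=NN2CC=O)c(OC)c1OC` gives 610 nM.

Compound 1 and compound 2 differ in one place only: hydrogen in place of methoxy on an aromatic carbon. That change produced a 1.6-fold higher number from compound 1 to compound 2 (0.22 log units; within the scatter), so the two values cannot be told apart with confidence. Compound 3 is built from the same atoms as compound 1, joined differently; the difference between the two cores is not broken down here. Among the compounds with values here, its value is the lowest of the three so far, yet it sits within the scatter of compound 1 and only beyond it relative to compound 2.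

Compound 4 `COc1ccc(C2CC(c3ccc4ccccc4c3)=NN2CC=O)cc1OC` has not yet been measured. It stands to compound 3 exactly as compound 2 stands to compound 1: hydrogen in place of methoxy on an aromatic carbon. The surroundings of the change are described in the same words for both pairs, so this is the same change on a different core. In this assay the step from compound 3 to compound 4 is expected to be a 1.6-fold higher number from compound 3 to compound 4 (0.19 log units; within the scatter), because the same change gave a 1.6-fold higher number from compound 1 to compound 2 (0.22 log units; within the scatter). Compound 4 is therefore estimated at 950 nM, with a likely range from 500 nM to 1900 nM.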

Compound 4, half-maximal inhibitory concentration: 1980 nM
Beside the measured number, compound 4's estimate is 2.1-fold (0.32 log units) below it; measured number outside the range, above it.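

In this assay, putting hydrogen in place of methoxy on an aromatic carbon gave a 3.2-fold higher number from compound 3 to compound 4 (0.51 log units; beyond the scatter), so on this core the change stands clear of the usual variation between repeat measurements. Set beside the same change on the other core, the two steps cannot be told apart in size: the same change on two cores in this assay, a 1.6-fold higher number (0.22 log units; within the scatter) from compound 1 to compound 2 and a 3.2-fold higher number (0.51 log units; beyond the scatter) from compound 3 to compound 4, 2.0-fold (0.29 log units) apart, within the scatter of two such steps. This shows that the change carried over from the core of compound 1 to the core of compound 3 with no detectable difference in size, even though only the second step is beyond the scatter, but two pairs do not show that its size is fixed or that it would hold on a third core.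

The compounds shown leave open how any other group would behave at this place on the aromatic ring, since only methoxy and hydrogen appear there; a hydroxy group, a fluorine atom or an amine might give a different result. They also leave open what removing the remaining methoxy groups would do.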